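This account rests on a few compounds, and the source may have more. Where it says the series, first, only, none or still open, it means among the compounds named here.

Working notes on the series. Compound 1 `O=S(=O)(Nc1ccccc1NS(=O)(=O)c1ccccc1)c1ccccc1` is the unsubstituted parent; in an assay for binding affinity to protein lin-28 homolog A (Mus musculus), with a stated time of 1 h (on this read-out lower numbers stand for stronger inhibition and higher numbers for weaker inhibition), compound 1 gives 32200 nM, the higher of the two measured values. Compound 2 `O=S(=O)(Nc1ccccc1NS(=O)(=O)c1ccc(F)cc1)c1ccccc1` carries a fluoro in place of hydrogen on an aromatic carbon; in this assay compound 2 gives 13900 nM, and the step is a 2.3-fold lower number from compound 1 to compound 2 (0.36 log units; beyond the scatter).

Compound 3 `Cc1ccc(NS(=O)(=O)c2ccccc2)c(NS(=O)(=O)c2ccccc2)c1` differs from compound 1 by methyl in place of hydrogen on an aromatic carbon. For the measured compounds named here, the methyl enters at a different aromatic carbon than the fluoro of compound 2, meta to a large group and para to a large group, so the single measured step, a 2.3-fold lower number from compound 1 to compound 2 (0.36 log units; beyond the scatter), bears on it only loosely: it shows that a small substituent on an aromatic carbon of this core can shift the number by a modest amount, but no substitution at the position taken by the methyl has been measured. In this assay the change is therefore expected to give no more than a modest step, with the direction uncertain and a slight lean toward a lower number; the expected step is a 1.3-fold lower number from compound 1 to compound 3 (0.11 log units; within the scatter). Compound 3 is estimated at 25000 nM, with a range from 9000 nM to 65000 nM.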

Compound 3, half-maximal inhibitory concentration: 28800 nM
Compound 3: the middle estimate sits 1.2-fold (0.06 log units) below what was measured; the measured number falls inside the stated range.
By their numbers in this assay, from the lowest: compound 2; then compounds 3 and 1 (each within the scatter of the next).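

In this assay, methyl in place of hydrogen on an aromatic carbon, meta to a large group and para to a large group, gives a 1.1-fold lower number from compound 1 to compound 3 (0.05 log units; within the scatter), so this first reading at this position shows no separation from the parent. The earlier step, a 2.3-fold lower number from compound 1 to compound 2 (0.36 log units; beyond the scatter), therefore does not extend to every small substituent on the shared core; it stays tied to a fluoro at a different aromatic carbon. Compound 2 and compound 3 differ in more than one place. The two steps can only be read separately against compound 1. No measured evidence on hand accounts for this result.

The compounds shown leave open whether the step seen with compound 2 belongs to the fluoro itself or to the carbon it occupies, since neither a fluoro at the methyl-bearing carbon nor a methyl at the fluoro-bearing carbon appears here. Also open, as far as these compounds go, is whether an amine, a carboxylic acid or a longer chain on the methyl-bearing carbon would move the number beyond the scatter.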